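The source may hold more compounds than are shown below. What is called first, only, known or untested is meant among the compounds shown, and "the series" means these compounds.

Of the compounds shown here, three built on one shared core have been measured in an assay on CHO-K1 cells for binding affinity to 5-hydroxytryptamine receptor 1B (Homo sapiens); on this read-out lower numbers stand for stronger inhibition and higher numbers for weaker inhibition. Compound 1 `CN(C)[C@H]1C[C@H](c2c[nH]c3ccc(C(N)=O)cc32)C1` gives 44.7 nM. Compound 2 `Cc1noc(Cc2ccc3[nH]cc([C@H]4C[C@H](N(C)C)C4)c3c2)n1` gives 1510 nM, and compound 3 `CN(C)[C@H]1C[C@H](c2c[nH]c3ccc(CC(N)=O)cc32)C1` gives 1350 nM, which places compound 3 second highest of the three, close to compound 2 and far from compound 1. Compound 4 `CN(C)[C@H]1C[C@H](c2c[nH]c3ccc(CN4C(=O)CNC4=O)cc32)C1` differs from compound 3 by 2,5-dioxoimidazolidin-1-yl in place of carbamoyl on a saturated chain carbon bound to an aromatic carbon. For the measured compounds named here, the closest precedent is the swap at the same chain carbon, which stayed within the scatter: a 1.1-fold lower number from compound 2 to compound 3 (0.05 log units; within the scatter). The steps of a 30-fold higher number from compound 1 to compound 3 (1.48 log units; beyond the scatter) and a 34-fold higher number from compound 1 to compound 2 (1.53 log units; beyond the scatter) show that both chain-linked groups lie far from compound 1. The step of a 1.0-fold higher number from compound 3 to compound 4 (0.02 log units; within the scatter) is therefore expected to stay within the scatter. Compound 4 is estimated at 1400 nM, with a range of 500 nM to 4000 nM.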

Compound 4, half-maximal inhibitory concentration: 6310 nM
The estimate for compound 4 lay 4.5-fold (0.65 log units) below the measured number; measured number outside the range, above it.
By their numbers in this assay, from the lowest: compound 1; then compounds 3 and 2 (each within the scatter of the next); then compound 4.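

In this assay, the saturated chain carbon bound to an aromatic carbon turns out not to treat every group alike: the earlier swap there stayed within the scatter, but 2,5-dioxoimidazolidin-1-yl gives a clear further loss (a 4.7-fold higher number from compound 3 to compound 4 (0.67 log units; beyond the scatter); a 4.2-fold higher number from compound 2 to compound 4 (0.62 log units; beyond the scatter)). The overall change from the shared starting point is also the largest seen so far (a 140-fold higher number from compound 1 to compound 4 (2.15 log units; beyond the scatter)), so the group on this carbon still matters once the chain is present. No measurement here explains this loss. As far as these compounds go, whether an amine or a carboxylic acid at this carbon would stay near compound 3 or fall toward compound 4 remains open.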